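Working notes: the step from compound 3 to compound 4

The source may hold more compounds than are shown below. What is called first, only, known or untested is meant among the compounds shown, and "the series" means these compounds.

Values so far in a functional assay on A549 cells (Homo sapiens) for cytotoxicity, read by MTT assay, with a stated time of 72 h; on this read-out higher numbers stand for weaker inhibition and lower numbers for stronger inhibition
compound 1 `CC[S+]([O-])CCCCN=C=S` gives 10200 nM
compound 2 `CCCC[S+]([O-])CCCCN=C=S` gives 9560 nM
compound 3 `CC(C)[S+]([O-])CCCCN=C=S` gives 10400 nM

Compound 3 gives 10400 nM and stands level with the other two compounds, since both steps that reach it are small (a 1.0-fold higher number from compound 1 to compound 3 (0.01 log units; within the scatter)) (a 1.1-fold higher number from compound 2 to compound 3 (0.04 log units; within the scatter)). The remaining pair looks the same (a 1.1-fold lower number from compound 1 to compound 2 (0.03 log units; within the scatter)).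

Compound 4 `CC(C)[S+]([O-])CCCCCN=C=S` has no value yet in this assay. The change is a group of 4 heavy atoms (2 carbon, 1 nitrogen, 1 sulfur; no ring) in place of a group of 3 heavy atoms (1 carbon, 1 nitrogen, 1 sulfur; no ring), on a saturated chain carbon, four bonds along the chain from a sulfur and nothing else. Among the measured compounds shown here, no measured step lies at that place. All three alter the group on a sulfur, so they bear on this change only indirectly. What they offer is a size: among these three compounds, no step goes beyond the scatter. No direct comparison exists for the place of this change, and that widens the range. No step beyond the scatter is therefore expected in this assay, and the expected step is small (a 1.1-fold lower number from compound 3 to compound 4 (0.04 log units; within the scatter)). For compound 4 the estimated value is 9500 nM (expected range 5000 nM to 18000 nM).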

Compound 4, half-maximal inhibitory concentration: 7750 nM
The estimate for compound 4 lay 1.2-fold (0.09 log units) above the measured number, and the stated range covers the measured number.
By their numbers in this assay, from the lowest: compounds 4, 2, 1 and 3 (each within the scatter of the next).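

In this assay, a group of 4 heavy atoms (2 carbon, 1 nitrogen, 1 sulfur; no ring) in place of a group of 3 heavy atoms (1 carbon, 1 nitrogen, 1 sulfur; no ring), on a saturated chain carbon, four bonds along the chain from a sulfur, gives a 1.3-fold lower number from compound 3 to compound 4 (0.13 log units; within the scatter) and so stays within the scatter. Among the compounds shown here, the earlier steps all altered the group on a sulfur, so this is the first direct reading at this place, and for this one pair the read-out does not separate the two groups. No supporting data bear on the origin of this small step.

As far as these compounds go, the reading rests on a single pair with isopropyl on the sulfur, so it remains open whether the same change gives a step of similar size with ethyl or butyl there. Also open, from the compounds shown here alone, is whether a longer chain at this place, or an amine or a carboxylic acid in place of the entering group, would give a step beyond the scatter in this assay or leave the numbers level with those of the present compounds.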